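The source may hold more compounds than are shown below. What is called first, only, known or untested is meant among the compounds shown, and "the series" means these compounds.

Working notes on the amide series. All three measured compounds share one core and differ only in the group on the carbonyl carbon. Compound 1 `CCN(Cc1ccccc1)C(=O)c1nn(-c2ccc(F)cc2)c(OC[C@@H](O)C[C@@H](O)CC(=O)O)c1C(C)C` gives 14 nM in an assay on microsomes from liver for inhibition of 3-hydroxy-3-methylglutaryl-coenzyme A reductase (Rattus norvegicus); on this read-out higher numbers stand for weaker inhibition and lower numbers for stronger inhibition. Compound 2 `CC(C)c1c(C(=O)N2CCCCC2)nn(-c2ccc(F)cc2)c1OC[C@@H](O)C[C@@H](O)CC(=O)O` gives 47 nM in this assay; the step of a 3.4-fold higher number from compound 1 to compound 2 (0.53 log units; beyond the scatter) is modest. Compound 3 `CC(C)c1c(C(=O)NCc2ccc(Cl)cc2)nn(-c2ccc(F)cc2)c1OC[C@@H](O)C[C@@H](O)CC(=O)O` gives 6.7 nM in this assay, the lowest of the three numbers, and both steps toward it, a 2.1-fold lower number from compound 1 to compound 3 (0.32 log units; beyond the scatter) and a 7.0-fold lower number from compound 2 to compound 3 (0.85 log units; beyond the scatter), lie beyond the scatter.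

Compound 4 `CC(C)c1c(C(=O)N(C)Cc2ccc(F)c(F)c2)nn(-c2ccc(F)cc2)c1OC[C@@H](O)C[C@@H](O)CC(=O)O` is not yet measured. The change is (3,4-difluorobenzyl)(methyl)amino in place of (4-chlorobenzyl)amino on a carbonyl carbon. Two of the measured steps bear on it. Compound 1 also carries a benzyl group together with a second alkyl group on the amide nitrogen, and compound 3 carries a benzyl group with the amide hydrogen; that pair gave a 2.1-fold lower number from compound 1 to compound 3 (0.32 log units; beyond the scatter). Compound 2, with no benzyl group at all, sits furthest away, so a benzyl group is retained in compound 4 and a large loss is not expected. A modest rise in the number, comparable to the gap between compound 3 and compound 1, is the working expectation. Compound 4 is therefore expected to give 12 nM, within 5 nM to 30 nM. Compound 4 is expected to show a 1.8-fold higher number from compound 3 to compound 4 (0.25 log units; within the scatter).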

Compound 4, half-maximal inhibitory concentration: 5.7 nM
The estimate for compound 4 lay 2.1-fold (0.32 log units) above the measured number; measured number inside the range.
By their numbers in this assay, from the lowest: compounds 4 and 3 (each within the scatter of the next); then compound 1; then compound 2.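

In this assay, replacing (4-chlorobenzyl)amino with (3,4-difluorobenzyl)(methyl)amino on the carbonyl carbon gives a 1.2-fold lower number from compound 3 to compound 4 (0.07 log units; within the scatter), so a substituted benzyl amide without the amide hydrogen can stay level with compound 3 on this read-out. The gap to compound 1 is not explained by the loss of the amide hydrogen alone: compound 1 lacks it too, yet the data show a 2.5-fold lower number from compound 1 to compound 4 (0.39 log units; beyond the scatter), and the piperidin-1-yl amide remains well apart, with an 8.2-fold lower number from compound 2 to compound 4 (0.92 log units; beyond the scatter). Nothing shown gives a measured reason for any of these steps.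

The compounds shown leave open how much of the result belongs to the methyl on the amide nitrogen and how much to the two fluorines, as both enter together in compound 4; a (4-chlorobenzyl)(methyl)amino amide would separate them. Going by these compounds, how far this position stays permissive is also open, and a longer chain in place of the methyl, or a benzyl ring carrying a nitrile or a carboxylic acid, would test it.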